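Ester to acid: an expected step on a CDK8 series

This account rests on a few compounds, and the source may have more. Where it says the series, first, only, none or still open, it means among the compounds named here.

Measured so far:
compound 1 `CCOC(=O)/C=C/c1ccncc1-c1ccc2c(cnn2C)c1`: 102 nM
compound 2 `O=C(/C=C/c1ccncc1-c1ccc2cccnc2c1)N1CCOCC1`: "not determined" (no result reported)
compound 3 `O=C(/C=C/c1ccncc1-c1ccc2cc[nH]c2c1)N1CCOCC1`: 43.9 nM

In an assay on a protein complex for inhibition of CDK8/Cyclin C (Homo sapiens), with a stated time of 1 h (on this read-out higher numbers stand for weaker inhibition and lower numbers for stronger inhibition), compound 1 gives 102 nM, the higher of the two numbers available; compound 3, with 43.9 nM, stands at a lower number, and that gap lies beyond the usual scatter. Compound 2 has no value in this assay. Compound 4 `Cn1ncc2cc(-c3cnccc3/C=C/C(=O)O)ccc21` is not yet measured. It differs from compound 1 by hydrogen in place of ethyl on an oxygen next to a carbonyl group. Within the data shown here, since no measured pair shows this change, its effect is only a guess: a modest weakening is expected, so the step from compound 1 to compound 4 in this assay is estimated as a 2.5-fold higher number from compound 1 to compound 4 (0.39 log units; beyond the scatter). Compound 4 is therefore expected to give about 250 nM, within 60 nM to 1000 nM.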

Compound 4, half-maximal inhibitory concentration: 34.6 nM
For compound 4 the middle estimate is 7.2-fold (0.86 log units) above the measured one; the measured number lies below the stated range.
By their numbers in this assay, from the lowest: compounds 4 and 3 (each within the scatter of the next); then compound 1.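

In this assay, hydrogen in place of ethyl on an oxygen next to a carbonyl group gives a 2.9-fold lower number from compound 1 to compound 4 (0.47 log units; beyond the scatter), a modest step toward stronger inhibition. This is the only single-place step shown, and it indicates that, on this core, the ethyl group is not needed to keep this level of inhibition. Nothing available explains the direction of this step.

The compounds shown leave open whether a primary amide or a methyl ester at this place would match the carboxy group. They also leave open whether the same change would hold on another core.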